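A 2-fluorophenyl Analogue and Its Expected Cytotoxicity

A few compounds are considered here, and "the series" means these few. Any claim that something is new, unique, unknown or untested is made for them only; others in the source may bear on it.

Compound 1, `CCN(CC)c1ccc(-c2cc(Cl)cn3c([N+](=O)[O-])c(CS(=O)(=O)c4ccccc4)nc23)cc1`: in an ADME assay on HepG2 cells (Homo sapiens) for cytotoxicity, read by MTT assay, with a stated time of 72 h (on this read-out higher numbers stand for lower toxicity in this test and lower numbers for higher toxicity in this test), compound 1 gives only a limit, > 15600 nM.
Compound 2, `O=Cc1ccc(-c2cc(Cl)cn3c([N+](=O)[O-])c(CS(=O)(=O)c4ccccc4)nc23)cc1`: in this assay compound 2 gives only a limit, > 31200 nM.

Compound 1 therefore stands only at a limit in this assay, with no exact number behind it (the limit of > 15600 nM in this assay, at which 1 of the 2 values shown sits). For the measured compounds named here, the one further value shown is likewise a limit (the limit of > 31200 nM in this assay, at which 1 of the 2 values shown sits). Going by the values given here, the sole measured step, a step that the two limits leave unreadable from compound 1 to compound 2, is left unreadable by those two limits, so its size cannot guide anything.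

Compound 3, `O=[N+]([O-])c1c(CS(=O)(=O)c2ccccc2)nc2c(-c3ccccc3F)cc(Cl)cn12`, differs from compound 1 by 2-fluorophenyl in place of 4-(diethylamino)phenyl on an aromatic carbon. No readable step bears on this change. With nothing pointing in either direction, compound 3 is expected to stay in the same region as compound 1, and its estimate in this assay is 30000 nM, within a range from 10000 nM to 100000 nM. The step that the limit leaves unreadable from compound 1 to compound 3 that this estimate means is expected to remain within the scatter, most likely again as a limit rather than a number.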

Compound 3, half-maximal cytotoxic concentration: > 3900 nM
Compound 3: no number, only a limit; the forecaster's own chance of this, stated with the estimate: 80%; the middle value is on the limit's open side.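

Compound 3, like compound 1 and compound 2, gives only a limit in this assay, and the steps from compound 1 and from compound 2 to compound 3 cannot be read. The compounds shown leave open whether changing the group on this aromatic carbon alters cytotoxicity at all.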